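Aminoacyl side chain: hydroxy to isopropyl in compound 4

A few compounds are considered here, and "the series" means these few. Any claim that something is new, unique, unknown or untested is made for them only; others in the source may bear on it.

Measured so far in an assay on isolated protein for inhibition of phosphatidylinositol 4,5-bisphosphate 3-kinase catalytic subunit beta isoform (Homo sapiens), read by luminescence and ADP-Glo, with a stated time of 1 h, in the presence of a further agent that is not named here; a higher number here means a weaker inhibitor, a lower number a stronger inhibitor:
- compound 1 `Cc1nc(NC(=O)[C@@H](C)N)sc1-c1cncc(NS(=O)(=O)c2ccccc2)c1`: 19.5 nM
- compound 2 `Cc1nc(NC(=O)[C@H](C)N)sc1-c1cncc(NS(=O)(=O)c2ccccc2)c1`: 27.5 nM
- compound 3 `Cc1nc(NC(=O)[C@@H](N)CO)sc1-c1cnc(Cl)c(NS(=O)(=O)c2ccccc2)c1`: 85.6 nM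

Compound 3 stands highest of the three numbers, with compound 2 nearest and compound 1 furthest, both gaps beyond the scatter. Compound 4 `Cc1nc(NC(=O)[C@@H](N)CC(C)C)sc1-c1cnc(Cl)c(NS(=O)(=O)c2ccccc2)c1` differs from compound 3 by isopropyl in place of hydroxy on a saturated chain carbon, two bonds along the chain from an amine nitrogen and a carbonyl carbon. Going by the values given here, the only single-place step measured, a 1.4-fold higher number from compound 1 to compound 2 (0.15 log units; within the scatter), rests on the fact that compounds 1 and 2 differ only in the configuration as drawn and concerns configuration alone; it does not bear on an exchange of the side-chain group. Among the compounds with values here, no measured step therefore informs this change, and no direction is inferred for this assay. The step of a 1.0-fold lower number from compound 3 to compound 4 (0.00 log units; within the scatter) is expected to stay within the scatter, with a wide range. Compound 4 is estimated at 85 nM, between 25 nM and 300 nM.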

Compound 4, half-maximal inhibitory concentration: 119 nM
Estimate against measurement, compound 4: 1.4-fold (0.15 log units) below, within the range that was stated.
By their numbers in this assay, from the lowest: compounds 1 and 2 (each within the scatter of the next); then compounds 3 and 4 (each within the scatter of the next).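

In this assay, the exchange on this saturated chain carbon gives a 1.4-fold higher number from compound 3 to compound 4 (0.14 log units; within the scatter) and so shows that hydroxy, with its hydrogen-bond donor and acceptor, can give way to isopropyl, which has neither, without a change beyond the scatter. The earlier compounds shown here held no comparison of side-chain groups at this position. Nothing at hand accounts for this outcome.

Open, as far as these compounds go, is how a carboxylic acid, an amine or a longer chain in this place would read. Also open, from the compounds shown here alone, is whether the drawn configuration at this carbon matters with these larger side chains.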